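The source may hold more compounds than are shown below. What is called first, only, known or untested is meant among the compounds shown, and "the series" means these compounds.

In an ADME assay on HEK293 cells (Homo sapiens) for cytotoxicity, read by MTT assay, with a stated time of 48 h (a lower number here means a stronger inhibitor, a higher number a weaker inhibitor), compound 1 `O=C1/C(=C\c2ccccc2)S/C(=N/c2ccccc2)N1Cc1ccncc1` gives 64700 nM, compound 2 `Cc1ccc(/C=C2/S/C(=N/c3ccccc3)N(Cc3ccncc3)C2=O)cc1` gives 49500 nM and compound 3 `O=C1/C(=C\c2ccc(O)c(O)c2)S/C(=N/c2ccccc2)N1Cc1ccncc1` gives 230000 nM, the highest of the three numbers. Compound 4 `O=C1/C(=C\c2cccc(O)c2)S/C(=N/c2ccccc2)N1Cc1ccncc1` is still unmeasured and differs from compound 3 by hydrogen in place of hydroxy on an aromatic carbon. Going by the values given here, no measured step removes a single hydroxy. The closest evidence is the replacement of phenyl by 3,4-dihydroxyphenyl, a 3.6-fold higher number from compound 1 to compound 3 (0.55 log units; beyond the scatter), and of 4-methylphenyl by 3,4-dihydroxyphenyl, a 4.6-fold higher number from compound 2 to compound 3 (0.67 log units; beyond the scatter). Both are modest, while a 1.3-fold lower number from compound 1 to compound 2 (0.12 log units; within the scatter) stays within the scatter. Compound 4 keeps one hydroxy, so a smaller step towards a lower number is expected, perhaps none beyond the scatter. The expected change is a 1.9-fold lower number from compound 3 to compound 4 (0.28 log units; within the scatter). For compound 4 the estimated value is 120000 nM, with an expected range of 60000 nM to 240000 nM.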

Compound 4, half-maximal inhibitory concentration: 150000 nM
For compound 4 the middle estimate is 1.3-fold (0.10 log units) below the measured one; measured number inside the range.
By their numbers in this assay, from the lowest: compounds 2 and 1 (each within the scatter of the next); then compounds 4 and 3 (each within the scatter of the next).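

In this assay the step from 3,4-dihydroxyphenyl to 3-hydroxyphenyl, with hydrogen replacing the hydroxy para to a large group, is a 1.5-fold lower number from compound 3 to compound 4 (0.19 log units; within the scatter) and lies within the scatter. With one hydroxy left, the gaps to the compounds without one remain, with a 2.3-fold higher number from compound 1 to compound 4 (0.37 log units; beyond the scatter) and a 3.0-fold higher number from compound 2 to compound 4 (0.48 log units; beyond the scatter) both beyond the scatter. The 3-hydroxyphenyl group alone thus separates compound 4 from compound 1 and compound 2, and the second hydroxy adds nothing beyond the scatter. Left open is whether a methoxy group or an amine on this aromatic carbon would read the same. No measured property of these compounds offers an explanation for this result.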